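Swapping the 5-hydroxypentyl chain of compound 2

The compounds below may be only part of what the source reports. "The series", "measured", "known", "first", "only" and "open" are said of these compounds alone.

- Compound 1 (`COc1nc(NC2CC2)c2ncn([C@H]3C[C@H](N=[N+]=[N-])[C@@H](CO)O3)c2n1`): > 100000 nM (a limit)
- Compound 2 (`[N-]=[N+]=N[C@H]1C[C@H](n2cnc3c(NCCCCCO)nc(N)nc32)O[C@@H]1CO`): > 100000 nM (a limit)
- Compound 3 (`COc1nc(F)nc2c1ncn2[C@H]1C[C@H](N=[N+]=[N-])[C@@H](CO)O1`): 9400 nM (a number)

These values come from an ADME assay on PBMC cells (Homo sapiens) for cytotoxicity, with a stated time of 5 days (on this read-out higher numbers stand for weaker inhibition and lower numbers for stronger inhibition), and describe how toxic each compound is to the cells. Compound 2 gives > 100000 nM (a limit and not a number). It stands at the limit of > 100000 nM in this assay, at which 2 of the 3 values shown sit (the other such compound is compound 1). Only compound 3 gives a true number, 9400 nM (its structure differs from compound 2 in more than one place).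

Compound 4 (`CC(CO)Nc1nc(N)nc2c1ncn2[C@H]1C[C@H](N=[N+]=[N-])[C@@H](CO)O1`) differs from compound 2 in one place, with 1-(hydroxymethyl)ethyl in place of 5-hydroxypentyl on a nitrogen on an aromatic ring. Among the compounds with values here, no measured pair shows what such a swap does, so no step beyond the usual scatter is expected in this assay for this change. The expected step of a number no higher from compound 2 to compound 4 (the limit leaves the size open) (an estimate) starts from a limit, so it is only a rough guide. Compound 4 is estimated at 100000 nM (range 30000 nM to 300000 nM) and may well also be reported only as a limit.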

Compound 4, half-maximal inhibitory concentration: > 100000 nM
Compound 4 ended at the assay's limit; the forecaster's own chance of this, stated with the estimate: 65%; the middle value sits exactly at the limit.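

Within the data shown here, compound 2 and compound 4 both stand at a limit of this assay rather than at a true number, so no step between them can be read: the limit of > 100000 nM in this assay, at which 3 of the 4 values shown sit. The compounds shown leave open whether swapping 5-hydroxypentyl for 1-(hydroxymethyl)ethyl changes toxicity to the cells at all.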